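The source may report more compounds than this note shows. Statements on the series, on what has been measured and on what is new or still open speak of the compounds shown alone.

Working notes on the series. In a functional assay on HCT-15 cells (Homo sapiens) for inhibition, read by sulforhodamine B assay, with a stated time of 48 h, tested at 10 uM (on this read-out higher numbers stand for a weaker effect at the one concentration tested and lower numbers for a stronger effect), compound 1 `COc1cc2cc(Oc3ccc(NC(=O)Nc4ccccc4)cc3)c(C)nc2cc1OC` gives 64.1%, compound 2 `COc1cc2cc(Oc3ccc(NC(=O)Nc4ccc(C)cc4)cc3)c(C)nc2cc1OC` gives 103% and compound 3 `COc1cc2cc(Oc3ccc(NC(=O)Nc4ccc(C(F)(F)F)cc4)cc3)c(C)nc2cc1OC` gives 75.4%. Compound 3 stands second highest of the three numbers; its nearest neighbour is reached by a number 11.3 percentage points higher from compound 1 to compound 3 (beyond the scatter), its furthest by a number 27.6 percentage points lower from compound 2 to compound 3 (beyond the scatter). The measured steps, a number 38.9 percentage points higher from compound 1 to compound 2 (beyond the scatter) and a number 27.6 percentage points lower from compound 2 to compound 3 (beyond the scatter), all concern which group sits on the aromatic carbon, not where it sits.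

Compound 4 `COc1cc2cc(Oc3ccc(NC(=O)Nc4cccc(C(F)(F)F)c4)cc3)c(C)nc2cc1OC` has not been measured. The change from compound 3 to compound 4 is 3-(trifluoromethyl)phenyl in place of 4-(trifluoromethyl)phenyl on an amide-type nitrogen. Among the measured compounds shown here, no measured step repositions a group on this ring, so none bears directly on the step; the spread among compounds 1, 2 and 3 shows only that changes on this ring can move this assay beyond the scatter in either direction. For the measured compounds named here, with no step of the same kind to lean on, the expectation is for no change beyond the scatter, a number 0.6 percentage points higher from compound 3 to compound 4 (within the scatter), with a wide range. Compound 4 is estimated at 76%, between 55% and 100%.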

Compound 4, a percentage reported as activity, at one concentration (the size of the read-out at that concentration, not a potency): 15.2%
Compound 4: the middle estimate sits 60.8 percentage points above what was measured; measured number below the stated range.
By their numbers in this assay, from the lowest: compound 4; then compound 1; then compound 3; then compound 2.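

In this assay, where the trifluoromethyl sits matters as well as which group is present: 3-(trifluoromethyl)phenyl in place of 4-(trifluoromethyl)phenyl gives a number 60.2 percentage points lower from compound 3 to compound 4 (beyond the scatter), towards a stronger effect with the same atoms joined differently. Set against the unsubstituted phenyl, the direction of the trifluoromethyl change now depends on its placement, with a number 11.3 percentage points higher from compound 1 to compound 3 (beyond the scatter) but a number 48.9 percentage points lower from compound 1 to compound 4 (beyond the scatter), and the gap to the 4-methylphenyl compound is wider still, at a number 87.8 percentage points lower from compound 2 to compound 4 (beyond the scatter). Nothing available explains this difference between the two placements.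

Going by these compounds, whether the stronger effect belongs to trifluoromethyl or would also appear with a chlorine, a methoxy group or a nitrile in its place remains open. The compounds shown also leave open how compound 4 behaves at other concentrations.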